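This account rests on a few compounds, and the source may have more. Where it says the series, first, only, none or still open, it means among the compounds named here.

Measured compounds: compound 1 `CCOC(=O)c1ccc(-c2nn(Cc3ccc(Cl)cc3)c3ccccc23)cc1`, compound 2 `CCOC(=O)c1ccc(-c2nn(Cc3ccccn3)c3ccccc23)cc1`, compound 3 `O=C(O)c1ccc(-c2nn(Cc3ccccc3)c3ccccc23)cc1`.

In a functional assay on cells (Platelet, Homo sapiens) for inhibition (a higher number here means a weaker inhibitor, a lower number a stronger inhibitor), compound 1 gives 120 nM. In this assay compound 2 gives 290 nM. Among the measured compounds shown here, the single step with a number, a 2.4-fold higher number from compound 1 to compound 2 (0.38 log units; beyond the scatter), is modest. For the measured compounds named here, for compound 3 the assay reports only a limit, > 10000 nM, and it is the one compound that sits at the limit of > 10000 nM in this assay, at which 1 of the 3 values shown sits. Compound 3 therefore stands apart from compound 1 and compound 2, which both return numbers.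

Compound 4 `OCc1ccc(-c2nn(Cc3ccccc3)c3ccccc23)cc1` differs from compound 3 in one place: hydroxymethyl in place of carboxy on an aromatic carbon. Going by the values given here, no measured step covers a change at this position, so the only guide is that compound 3 alone reaches the limit while the two compounds without the carboxy group return numbers. The step from compound 3 to compound 4 is expected to bring the number down, and its size can only be estimated, an at least 5.0-fold lower number from compound 3 to compound 4 (0.69 log units; beyond the scatter). Compound 4 is estimated at 2000 nM in this assay, with a range from 300 nM to 10000 nM, and a real chance that the assay again reports only a limit.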

Compound 4, half-maximal inhibitory concentration: > 10000 nM
Compound 4: a limit, no number; the forecaster's own chance of this, stated with the estimate: 30%; at least 5.0-fold (0.69 log units) between middle value and limit.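

Compound 3 and compound 4 both sit at a limit in this assay, so no step between them can be read: the limit of > 10000 nM in this assay, at which 2 of the 4 values shown sit.

The compounds shown leave open whether hydroxymethyl in place of carboxy on an aromatic carbon changes inhibition at all.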